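The compounds below may be only part of what the source reports. "The series", "measured", "known", "first", "only" and "open" are said of these compounds alone.

Among the measured compounds shown here, in a functional assay on RT-112 cells (Homo sapiens) for antiproliferative activity, read by MTT assay, with a stated time of 72 h (on this read-out higher numbers stand for weaker inhibition of growth and lower numbers for stronger inhibition of growth), compound 3 `COc1cc(Nc2ncnc3c(NC(=O)Nc4ccc(C)cc4C)cccc23)cc(OC)c1` gives 1290 nM, the second highest of the three numbers measured so far. Compound 1 `COc1cc(NC(=O)Nc2cccc3c(Nc4cc(OC)cc(OC)c4)ncnc23)cc(OC)c1` gives a lower number, 366 nM, and compound 2 `COc1cc(Nc2ncnc3c(NC(=O)Nc4cccc(Oc5ccccc5)c4)cccc23)cc(OC)c1` a higher one, 14000 nM. Compound 4 `COc1cc(Nc2ncnc3c(NC(=O)Nc4ccc(C)c(C)c4)cccc23)cc(OC)c1`, not yet measured, carries 3,4-dimethylphenyl in place of 2,4-dimethylphenyl on an amide-type nitrogen.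

For the measured compounds named here, the only measured step at this place is a 3.5-fold higher number from compound 1 to compound 3 (0.55 log units; beyond the scatter), a modest change beyond the scatter that brought in 2,4-dimethylphenyl in place of 3,5-dimethoxyphenyl. Going by the values given here, no measured pair compares two dimethylphenyl groups, so that step serves only as a rough ceiling on size, and the swap here is expected to be smaller. The direction is poorly supported by the data, and only a slight move toward a lower number is assumed.

The expected step is a 1.4-fold lower number from compound 3 to compound 4 (0.16 log units; within the scatter), which stays within the scatter. For compound 4 the estimate in this assay is 900 nM, with an expected range from 300 nM to 3000 nM.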

Compound 4, concentration for 50% growth inhibition: 8.8 nM
Beside the measured number, compound 4's estimate is 100-fold (2.01 log units) above it, outside the stated range (below it).
By their numbers in this assay, from the lowest: compound 4; then compound 1; then compound 3; then compound 2.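

In this assay, a 150-fold lower number from compound 3 to compound 4 (2.17 log units; beyond the scatter) comes from rearranging the two methyl groups alone, since 2,4-dimethylphenyl and 3,4-dimethylphenyl match in heavy atoms and ring type, so this place on the amide-type nitrogen responds to the substitution pattern and not just to the kind of group present. The a 42-fold lower number from compound 1 to compound 4 (1.62 log units; beyond the scatter) shows that 3,4-dimethylphenyl also far outdoes 3,5-dimethoxyphenyl, so the earlier compounds had shown only a small part of the range this place can cover. Nothing available bears on why the pattern matters so much here.

Open, on these data alone, is whether both methyl groups are needed, or whether a plain phenyl or a monomethylphenyl would keep the low number. Also open, as far as these compounds go, is whether chloro or ethyl groups could replace the methyl groups of 3,4-dimethylphenyl.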